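A side chain exchanged on a cytotoxic compound

This account rests on a few compounds, and the source may have more. Where it says the series, first, only, none or still open, it means among the compounds named here.

Measured compounds:
compound 1 `CCOC(=O)/C(C#N)=C/c1ccccc1-c1c(/C=C(\C#N)C(=O)OCC)cc(OC)c(OC)c1OC`: 6530 nM
compound 2 `COc1cc(C=C(C#N)C#N)c(-c2ccccc2C=C(C#N)C#N)c(OC)c1OC`: > 40000 nM (a limit of the assay)

The two compounds were tested in a functional assay on KB cells (Homo sapiens) for cytotoxicity, read by sulforhodamine B assay; on this read-out higher numbers stand for weaker inhibition of growth and lower numbers for stronger inhibition of growth. Among the measured compounds shown here, compound 1 gives 6530 nM, the only true number available. Compound 2 reaches only a limit of the assay, > 40000 nM. The two compounds differ in more than one place, so they offer no clean step to reason from.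

Compound 3 `CCOC(=O)/C(C#N)=C/c1ccccc1-c1c(C(=O)OC)cc(OC)c(OC)c1OC` has not yet been measured. Compared with compound 1, it carries methoxycarbonyl in place of 2-cyano-2-(ethoxycarbonyl)ethenyl on an aromatic carbon. For the measured compounds named here, no measured step covers this exchange, so any forecast in this assay is uncertain. Starting from compound 1 at 6530 nM, a moderate move toward weaker inhibition of growth is expected, possibly not much beyond the usual scatter. The estimated size of this change is a 1.8-fold higher number from compound 1 to compound 3 (0.26 log units; within the scatter). For compound 3 the expected value is 12000 nM, with an estimated range of 3500 nM to 40000 nM.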

Compound 3, concentration for 50% growth inhibition: > 40000 nM
Compound 3 was reported as a limit; the forecaster's own chance of this, stated with the estimate: 20%; at least 3.3-fold (0.52 log units) between middle value and limit.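

In this assay, among the compounds shown here, putting methoxycarbonyl in place of 2-cyano-2-(ethoxycarbonyl)ethenyl on this aromatic carbon gives an at least 6.1-fold higher number from compound 1 to compound 3 (0.78 log units; beyond the scatter), the first step that can be read from a change in one place. It shows that this position is not indifferent to its substituent: compound 1, with the larger 2-cyano-2-(ethoxycarbonyl)ethenyl group, gives a true number, whereas the exchange, which leaves the other 2-cyano-2-(ethoxycarbonyl)ethenyl group and the three methoxy groups untouched, is enough to take compound 3 to a limit of the assay. The step therefore fixes only a minimum size and not the real distance between the two compounds: the limit of > 40000 nM in this assay, at which 2 of the 3 values shown sit.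

The compounds shown leave open which part of the 2-cyano-2-(ethoxycarbonyl)ethenyl group matters at this carbon, whether the nitrile, the ethyl ester or the carbon-carbon double bond. They also leave open whether a carboxylic acid, an amine or a longer chain ending in an ester at this position would keep the growth inhibition seen with compound 1.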